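The source may report more compounds than this note shows. Statements on the series, on what has been measured and on what is new or still open speak of the compounds shown alone.

In a functional assay on LNCaP cells (Homo sapiens) for antiproliferative activity, read by propidium iodide staining, with a stated time of 96 h (a lower number here means a stronger inhibitor, a higher number a weaker inhibitor), compound 3 (`CC(O)(COc1ccc(C#N)cc1)C(=O)Nc1ccc(S(F)(F)(F)(F)F)cc1`) gives 100000 nM as the highest number of the three measured, with compound 1 (`CC(O)(CSc1ccc(F)cc1)C(=O)Nc1ccc(S(F)(F)(F)(F)F)cc1`) at 12500 nM and compound 2 (`CC(O)(COc1ccccc1C(F)(F)F)C(=O)Nc1ccc(S(F)(F)(F)(F)F)cc1`) at 1200 nM on the same read-out. The change to compound 4 (`CC(O)(COc1ccc(C#N)cc1C(F)(F)F)C(=O)Nc1ccc(S(F)(F)(F)(F)F)cc1`) is trifluoromethyl in place of hydrogen on an aromatic carbon in the form of trifluoromethyl in place of hydrogen on an aromatic carbon, ortho to a large group and meta to a cyano group.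

Within the data shown here, two measured steps bear on this. The large one, an 83-fold higher number from compound 2 to compound 3 (1.92 log units; beyond the scatter) as 4-cyanophenyl replaces 2-(trifluoromethyl)phenyl, removes a trifluoromethyl group and adds a cyano group at once, and compound 4 carries both groups. The modest one, an 8.0-fold higher number from compound 1 to compound 3 (0.90 log units; beyond the scatter) in a swap of the whole side group, bears only loosely. Among the measured compounds shown here, no measured step isolates the trifluoromethyl group alone.

A move to a lower number is therefore expected, sizeable but short of the large step. The expected step is a 17-fold lower number from compound 3 to compound 4 (1.22 log units; beyond the scatter) in this assay on this reasoning. The estimate for compound 4 is 6000 nM (expected range 1000 nM to 40000 nM).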

Compound 4, half-maximal inhibitory concentration: 100000 nM
The estimate for compound 4 lay 17-fold (1.22 log units) below the measured number; measured number above the stated range.
By their numbers in this assay, from the lowest: compound 2; then compound 1; then compounds 3 and 4 (each within the scatter of the next).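

In this assay, trifluoromethyl on the aromatic carbon ortho to a large group and meta to a cyano group gives no change at the digits printed from compound 3 to compound 4 (within the scatter), so this change brings no gain while the cyano group is present. Among these compounds, the companion step, an 83-fold higher number from compound 2 to compound 4 (1.92 log units; beyond the scatter), is the first to isolate the cyano group, as cyano in place of hydrogen on an aromatic carbon with trifluoromethyl retained, and it alone is as large as the earlier mixed change between compound 2 and compound 3. The data give no reason for either step.

Going by these compounds, whether an amine or a carboxylic acid in the place of the cyano group would keep a number close to that of compound 2 remains open. Also open, on these data alone, is whether the cyano group has a step of similar size on the sulfur-linked side group of compound 1.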